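Working notes on the step from compound 3 to compound 4

This account rests on a few compounds, and the source may have more. Where it says the series, first, only, none or still open, it means among the compounds named here.

Compound 1, `O=C(NCc1ccccc1)c1cn(-c2ccccc2)nc1-c1ccncc1`, in a functional assay on HeLa cells (Homo sapiens) for cytotoxicity, read by MTT assay, with a stated time of 48 h (a higher number here means a weaker inhibitor, a lower number a stronger inhibitor), gives > 100000 nM, which is a limit of the assay and not a number.
Compound 2, `COc1ccc(OC(=O)c2cn(-c3ccccc3)nc2-c2ccncc2)cc1`, in this assay gives > 100000 nM, again a limit.
Compound 3, `CCc1ccc(OC(=O)c2cn(-c3ccccc3)nc2-c2ccncc2)cc1`, in this assay gives > 100000 nM, also a limit.

Compound 3 therefore stands at the limit of this assay, the same limit at which every value of the series sits (the limit of > 100000 nM in this assay, at which 3 of the 3 values shown sit). Going by the values given here, none of the measured steps can be read: a step that the two limits leave unreadable from compound 1 to compound 2, a step that the two limits leave unreadable from compound 1 to compound 3 and a step that the two limits leave unreadable from compound 2 to compound 3 all run between two limits and give no size or direction.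

The unmeasured compound 4, `CC(C)(C)c1ccc(OC(=O)c2cn(-c3ccccc3)nc2-c2ccncc2)cc1`, differs from compound 3 by tert-butyl in place of ethyl on an aromatic carbon. Among the compounds with values here, no measured step bears on an alkyl change of this kind; the change from methoxy to ethyl on the same aromatic carbon is the closest comparison, and it too lies between two limits. The expectation in this assay is therefore no readable step beyond the scatter, and most likely another limit. The step from compound 3 to compound 4 is estimated as a number no higher from compound 3 to compound 4 (the limit leaves the size open). Compound 4 is expected to give about 100000 nM in this assay, within a range of 30000 nM to 300000 nM.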

Compound 4, half-maximal inhibitory concentration: 35400 nM
For compound 4 the middle estimate is 2.8-fold (0.45 log units) above the measured one; the range from low to high includes it.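

Going by these compounds alone, at this aromatic carbon, para to a large group, tert-butyl in place of ethyl gives the only readable change so far in this assay: an at least 2.8-fold lower number from compound 3 to compound 4 (0.45 log units; beyond the scatter). With tert-butyl in place of methoxy at the same carbon, the series shows an at least 2.8-fold lower number from compound 2 to compound 4 (0.45 log units; beyond the scatter), so two different groups at this position are now separated from tert-butyl, whereas the steps among compound 1, compound 2 and compound 3 cannot be read. Compound 4 therefore marks this position as one at which the read-out can move off the limit, and it is the only compound shown with a value that is a number rather than a limit: the limit of > 100000 nM in this assay, at which 3 of the 4 values shown sit.

From the compounds shown here alone, both readable steps start from a limit, so their full size stays open, and ethyl and tert-butyl alone do not tell whether the change follows the size of the alkyl group. Also open, going by these compounds, is how isopropyl, a longer chain such as n-butyl, or an amine or a carboxylic acid at this carbon would read in this assay.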